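Removing the allyl from a sulfur on two related cores

The source may hold more compounds than are shown below. What is called first, only, known or untested is meant among the compounds shown, and "the series" means these compounds.

Compound 1 `C=CCSc1nncc2c(CC)ncn12` and compound 2 `CCc1ncn2c(S)nncc12` share one core and differ in a single place: hydrogen in place of allyl on a sulfur. In a functional assay for inhibition, with Homo sapiens as the target (a higher number here means a weaker inhibitor, a lower number a stronger inhibitor), compound 1 gives > 48000 nM, which is a limit of the assay and not a number. In this assay compound 2 likewise gives only a limit, > 48000 nM. The step that the two limits leave unreadable from compound 1 to compound 2 is therefore not readable, since both of its ends rest on (the limit of > 48000 nM in this assay, at which 3 of the 3 values shown sit).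

Compound 3 `C=CCSc1nncc2c(C)nc(-c3ccccc3)n12` carries a different core; the difference between the core of compound 1 and the core of compound 3 is not broken down here. In this assay compound 3 also gives only a limit, > 48000 nM. Compound 4 `Cc1nc(-c2ccccc2)n2c(S)nncc12` has not yet been measured and differs from compound 3 by hydrogen in place of allyl on a sulfur, the same change as that from compound 1 to compound 2, made at the same kind of place.

No measured step among these compounds is readable, so no size can be carried over. Going by the values given here, what can be said is that every value shown sits at the limit of > 48000 nM in this assay, at which 3 of the 3 values shown sit, and the one earlier instance of this change left both partners at that limit. Compound 4 is therefore expected to give 100000 nM in this assay, with a range of 20000 nM to 1000000 nM allowed. The corresponding expected step that the limit leaves unreadable from compound 3 to compound 4 is an estimate with no readable precedent behind it, and the most likely outcome for compound 4 is again a limit rather than a number.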

Compound 4, half-maximal inhibitory concentration: > 48000 nM
Compound 4 ended at the assay's limit; the forecaster's own chance of this, stated with the estimate: 85%; the middle value is on the limit's open side.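

In this assay compound 4 gives > 48000 nM, which is a limit of the assay and not a number. The step from compound 3 to compound 4 therefore cannot be read, as both of its ends rest on a limit: the limit of > 48000 nM in this assay, at which 4 of the 4 values shown sit. The compounds shown leave open whether hydrogen in place of allyl on a sulfur changes inhibition at all on either core.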